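From a dimethylcarbamoyl chain to a 3-hydroxypropyl chain

The source may report more compounds than this note shows. Statements on the series, on what has been measured and on what is new or still open speak of the compounds shown alone.

Values in an ADME assay on L929 cells (Mus musculus) for cytotoxicity, read by resazurin assay, with a stated time of 48 h (on this read-out lower numbers stand for higher toxicity in this test and higher numbers for lower toxicity in this test), so far:
Compound 1 (`C=CCn1c2ccc([N+](=O)[O-])cc2c(=O)n1Cc1ccccc1`) gives 192000 nM as a number
Compound 2 (`NC(=O)CCCn1c2ccc([N+](=O)[O-])cc2c(=O)n1Cc1ccccc1`) gives > 256000 nM as a limit
Compound 3 (`CN(C)C(=O)CCCn1c2ccc([N+](=O)[O-])cc2c(=O)n1Cc1ccccc1`) gives > 256000 nM as a limit

Compound 3 stands at the limit of > 256000 nM in this assay, at which 2 of the 3 values shown sit, and has no number of its own. Compound 4 (`O=c1c2cc([N+](=O)[O-])ccc2n(CCCO)n1Cc1ccccc1`) carries hydroxy in place of dimethylcarbamoyl on a saturated chain carbon, three bonds along the chain from an aromatic nitrogen. Among the compounds with values here, two measured steps bear on this chain (an at least 1.3-fold higher number from compound 1 to compound 2 (0.12 log units; that floor lies within the scatter)) and (an at least 1.3-fold higher number from compound 1 to compound 3 (0.12 log units; that floor lies within the scatter)), and the third gives no size (a step that the two limits leave unreadable from compound 2 to compound 3). With only those floors to go on, the expected change in this assay is none beyond the scatter (an at least 1.0-fold lower number from compound 3 to compound 4 (0.02 log units; that floor lies within the scatter)). For compound 4 the estimated value is 240000 nM with an expected range (120000 nM to 450000 nM).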

Compound 4, concentration lethal to 50% of the cells: > 256000 nM
Compound 4: no number, only a limit; the forecaster's own chance of this, stated with the estimate: 55%; middle value at least 1.0-fold (0.02 log units) away from the limit.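

In this assay compound 4 gives > 256000 nM, a limit and not a number, so a chain end without a carbonyl, 3-hydroxypropyl, reaches the same limit as the amide chains: the limit of > 256000 nM in this assay, at which 3 of the 4 values shown sit. The steps linking compound 4 with compound 2 and compound 3 cannot be read, since both ends of each are limits. The one readable step is an at least 1.3-fold higher number from compound 1 to compound 4 (0.12 log units; that floor lies within the scatter), so a real gain is neither shown nor excluded.

From the compounds shown here alone, whether an amine, a carboxylic acid or a longer chain at this position would give a number in this assay stays open. So does any order among compound 2, compound 3 and compound 4.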